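Chain shortening of hydroxamic acids across two cores

The source may hold more compounds than are shown below. What is called first, only, known or untested is meant among the compounds shown, and "the series" means these compounds.

Compound 1 `CC(C)CCc1c(OCCCCCCCC(=O)NO)ccc2ccc(=O)oc12` gives 1730 nM in a functional assay on PC-3 cells (Homo sapiens) for antiproliferative activity, read by sulforhodamine B assay, with a stated time of 48 h; a lower number here means a stronger inhibitor of growth, a higher number a weaker inhibitor of growth. Compound 2 `CC(C)CCc1c(OCCCCCCC(=O)NO)ccc2ccc(=O)oc12` gives 520 nM in this assay; the change is hydroxycarbamoyl in place of (hydroxycarbamoyl)methyl on a saturated chain carbon, six bonds along the chain from an oxygen on an aromatic ring and it brought a 3.3-fold lower number from compound 1 to compound 2 (0.52 log units; beyond the scatter). Compound 3 `CC(C)CCc1c(OCCCCCC(=O)NO)ccc2c1OC(=O)CC2` carries its chain on a different core, and the difference between the two cores is not broken down here. In this assay compound 3 gives > 30000 nM, which is a limit of the assay and not a number, namely (the limit of > 30000 nM in this assay, at which 1 of the 3 values shown sits). Compound 4 `CC(C)CCc1c(OCCCCC(=O)NO)ccc2c1OC(=O)CC2` differs from compound 3 by hydroxycarbamoyl in place of (hydroxycarbamoyl)methyl on a saturated chain carbon, four bonds along the chain from an oxygen on an aromatic ring, the same kind of change as that from compound 1 to compound 2, here four bonds rather than six bonds along the chain from an oxygen on an aromatic ring. Resting on the step of a 3.3-fold lower number from compound 1 to compound 2 (0.52 log units; beyond the scatter), compound 4 is expected to show a number no higher from compound 3 to compound 4 (the limit leaves the size open). The estimate for compound 4 is 30000 nM, between 9000 nM and 100000 nM, with a real chance that only a limit is returned again.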

Compound 4, concentration for 50% growth inhibition: > 30000 nM
Compound 4 gave a limit, no number; the forecaster's own chance of this, stated with the estimate: 55%; the middle value lies on the limit itself.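

Compound 3 and compound 4 both return a limit of the assay and not a number, so no step between them can be read: the limit of > 30000 nM in this assay, at which 2 of the 4 values shown sit.

The compounds shown leave open whether chain length matters at all on the core of compound 3, and what the change of core alone does.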